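This account rests on a few compounds, and the source may have more. Where it says the series, first, only, none or still open, it means among the compounds named here.

Measured so far: compound 1 `C[C@@H](NCC1CCN(CCCc2c[nH]c3ccc(-n4cnnc4)cc23)CC1)c1ccccc1` gives 14 nM in an assay on CHO cells for displacement of a labelled ligand from 5-hydroxytryptamine receptor 1B (Homo sapiens); on this read-out lower numbers stand for stronger inhibition and higher numbers for weaker inhibition; compound 2 `c1ccc(CNCC2CCN(CCCc3c[nH]c4ccc(-n5cnnc5)cc34)CC2)cc1` gives 28 nM; compound 3 `O[C@@H]1Cc2ccccc2[C@H]1NC1CCN(CCCc2c[nH]c3ccc(-n4cnnc4)cc23)CC1` gives 210 nM.

Compound 1 stands lowest of the three numbers, with compound 2 nearest a 2.0-fold higher number from compound 1 to compound 2 (0.30 log units; within the scatter) and compound 3 furthest a 15-fold higher number from compound 1 to compound 3 (1.18 log units; beyond the scatter). Compound 4 `CN(C1CCN(CCCc2c[nH]c3ccc(-n4cnnc4)cc23)CC1)S(=O)(=O)c1ccccc1` differs from compound 1 by methyl(phenylsulfonyl)amino in place of ((1-phenylethyl)amino)methyl on a saturated ring carbon. Among the compounds with values here, the steps that bear on this are those toward compound 3, which also attaches the group straight to the ring carbon: a 15-fold higher number from compound 1 to compound 3 (1.18 log units; beyond the scatter) and a 7.5-fold higher number from compound 2 to compound 3 (0.88 log units; beyond the scatter). Both point to a sizeable loss. Compound 4 is therefore expected to land well above compound 1, by about a 14-fold higher number from compound 1 to compound 4 (1.15 log units; beyond the scatter). The estimate for compound 4 in this assay is 200 nM, with a range from 40 nM to 1000 nM.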

Compound 4, half-maximal inhibitory concentration: 10 nM
Beside the measured number, compound 4's estimate is 20-fold (1.30 log units) above it, outside the stated range (below it).
By their numbers in this assay, from the lowest: compounds 4, 1 and 2 (each within the scatter of the next, the first and the last beyond it); then compound 3.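

In this assay, a group attached straight to the saturated ring carbon does not by itself mean a loss: methyl(phenylsulfonyl)amino, with no hydrogen-bond donor, gives a 1.4-fold lower number from compound 1 to compound 4 (0.15 log units; within the scatter). Two further steps show the same position reading differently with different groups, a 21-fold lower number from compound 3 to compound 4 (1.32 log units; beyond the scatter) and a 2.8-fold lower number from compound 2 to compound 4 (0.45 log units; beyond the scatter). No measurement shown accounts for these differences.

From the compounds shown here alone, what remains open is whether the methyl on the sulfonamide nitrogen matters, and how a benzoyl amide would read in place of the phenylsulfonyl group.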